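This account rests on a few compounds, and the source may have more. Where it says the series, first, only, none or still open, it means among the compounds named here.

Measured so far in an assay on Cerebral cortex for displacement of a labelled ligand from adenosine receptor A1 (Bos taurus); a higher number here means a weaker inhibitor, a lower number a stronger inhibitor:

compound 1 `c1ccc(Cn2nnc3c(NC4CCC4)nc(-c4ccccc4)nc32)cc1`, 5 nM
compound 2 `Clc1ccccc1Cn1nnc2c(NC3CCC3)nc(-c3ccccc3)nc21`, 24 nM
compound 3 `c1ccc(Cn2nnc3c(NC4CCCC4)nc(-c4ccccc4)nc32)cc1`, 11 nM

Compound 2 differs from compound 1 by chloro in place of hydrogen on an aromatic carbon. That change gave a 4.8-fold higher number from compound 1 to compound 2 (0.68 log units; beyond the scatter). Compound 3 differs from compound 1 by cyclopentyl in place of cyclobutyl on a nitrogen on an aromatic ring, and that change gave a 2.2-fold higher number from compound 1 to compound 3 (0.34 log units; beyond the scatter). Compound 2 and compound 3 have no step counted between them; their values in this assay simply stand as given above.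

Compound 4 `Clc1ccccc1Cn1nnc2c(NC3CCCC3)nc(-c3ccccc3)nc21` is not yet measured. It differs from compound 3 by chloro in place of hydrogen on an aromatic carbon. Among the measured compounds shown here, this is the same change as the one from compound 1 to compound 2: the place of the change is described in the same words for both pairs, and the two cores differ only in the way given for compound 1 and compound 3. Among the compounds shown this change occurs twice, once measured and once not.

For compound 4 in this assay the step is expected to resemble the measured one, a 4.5-fold higher number from compound 3 to compound 4 (0.66 log units; beyond the scatter), because the step from compound 1 to compound 2 was a 4.8-fold higher number from compound 1 to compound 2 (0.68 log units; beyond the scatter) on the same change at the same place. For the measured compounds named here, only one measured instance supports this, so the range is kept wide. Compound 4 is estimated at 50 nM, between 20 nM and 130 nM.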

Compound 4, inhibition constant: 9 nM
The estimate for compound 4 lay 5.6-fold (0.74 log units) above the measured number; the whole stated range lies above it.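

In this assay, 2-chlorobenzyl in place of benzyl gives a 1.2-fold lower number from compound 3 to compound 4 (0.09 log units; within the scatter), so the chloro change does not carry over intact from the core of compound 1 to the core of compound 3: the same change on two cores in this assay, a 4.8-fold higher number (0.68 log units; beyond the scatter) from compound 1 to compound 2 and a 1.2-fold lower number (0.09 log units; within the scatter) from compound 3 to compound 4, 5.9-fold (0.77 log units) apart, beyond the scatter of two such steps.
The swap of cyclobutyl for cyclopentyl on the nitrogen also depends on its partner, giving a 2.7-fold lower number from compound 2 to compound 4 (0.43 log units; beyond the scatter) with the chloro present, and its direction is reversed from the step without the chloro: the same change on two cores in this assay, a 2.2-fold higher number (0.34 log units; beyond the scatter) from compound 1 to compound 3 and a 2.7-fold lower number (0.43 log units; beyond the scatter) from compound 2 to compound 4, 5.9-fold (0.77 log units) apart, beyond the scatter of two such steps.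
The two changes therefore do not add up across these four compounds, but this single set of four does not show why, nor how either change would behave on any other core.

On these data alone, whether fluoro or methoxy in place of the chloro on the same aromatic carbon would show the same dependence on the nitrogen substituent remains open. Also open, as far as these compounds go, is whether cyclopropyl or cyclohexyl on that nitrogen would follow the cyclobutyl pair or the cyclopentyl pair.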